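The compounds below may be only part of what the source reports. "The series", "measured", "known", "first", "only" and "open" are said of these compounds alone.

Of the compounds shown here, two built on a shared core have been measured in an assay on HEK293 cells for agonist activity at transient receptor potential cation channel subfamily M member 8 (Homo sapiens), read by fluorescence and calcium flux, with a stated time of 15 min; on this read-out lower numbers stand for an effect already at smaller amounts and higher numbers for an effect only at larger amounts of compound. Compound 1, `CCC(C)N(Cc1cccs1)C(=O)COc1ccc(C)cc1`, gives 2000 nM, and compound 2, `C=CCN(Cc1cccs1)C(=O)COc1ccc(C)cc1`, gives 20 nM. Going by the values given here, of these two numbers compound 2 holds the lower one, with compound 1 as its only neighbour, and the single measured step, a 100-fold lower number from compound 1 to compound 2 (2.00 log units; beyond the scatter), shows that the group on the amide-type nitrogen matters strongly at this spot. Compound 3, `Cc1ccc(OCC(=O)N(Cc2cccs2)c2cnccn2)cc1`, differs from compound 2 in one place: pyrazin-2-yl in place of allyl on an amide-type nitrogen. Among the compounds with values here, no measured pair puts an aromatic ring at this position, so the step from compound 1 to compound 2 bears on it only loosely, by showing how sensitive this position is. A step beyond the scatter is therefore expected, more likely toward a higher number than a lower one, with wide uncertainty. For compound 3 the estimate is 200 nM, within a range from 20 nM to 3000 nM. That estimate means an expected step of a 10-fold higher number from compound 2 to compound 3 (1.00 log units; beyond the scatter).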

Compound 3, half-maximal effective concentration: 1240 nM
Estimate against measurement, compound 3: 6.2-fold (0.79 log units) below; the measured number falls inside the stated range.
By their numbers in this assay, from the lowest: compound 2; then compounds 3 and 1 (each within the scatter of the next).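

The position on the amide-type nitrogen accepts an aromatic ring only at a cost in this assay: pyrazin-2-yl in place of allyl brings a 62-fold higher number from compound 2 to compound 3 (1.79 log units; beyond the scatter) and so a large loss of the low number. Pyrazin-2-yl in place of sec-butyl brings a 1.6-fold lower number from compound 1 to compound 3 (0.21 log units; within the scatter) and so no readable change, even though a six-membered aromatic ring with hetero atoms has replaced a chain. Among these three compounds, only allyl gives the low number, and nothing available explains why.

As far as these compounds go, how a propyl group, which is allyl without its double bond, would compare remains open. So does the result for a phenyl ring, which would show whether the ring nitrogens of pyrazin-2-yl play any part in these numbers.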